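Swapping hydroxymethyl for an aryl group in the series

The source may report more compounds than this note shows. Statements on the series, on what has been measured and on what is new or still open speak of the compounds shown alone.

Of the compounds shown here, two have been measured so far in a functional assay on the whole organism with Rattus norvegicus as the target; a lower number here means that less compound is needed, a higher number that more compound is needed for the effect. Compound 1 `Cc1cc(-c2csc(NC(=O)C(=O)O)n2)on1` gives 6 mg/kg. Compound 2 `O=C(O)C(=O)Nc1nc(-c2cc(CO)no2)cs1` gives 0.7 mg/kg, the lower of the two numbers.

The next compound is compound 3 `O=C(O)C(=O)Nc1nc(-c2cc(-c3c(F)cccc3Cl)no2)cs1`, with 2-chloro-6-fluorophenyl in place of hydroxymethyl on an aromatic carbon.

For the measured compounds named here, only one measured step bears on this change: an 8.6-fold lower number from compound 1 to compound 2 (0.93 log units; beyond the scatter). It is hydroxy in place of hydrogen on a saturated chain carbon bound to that same aromatic carbon, so the number in this assay does respond to a small edit at this place. The group in compound 3 carries no hydroxy, as in compound 1 at 6 mg/kg, which points towards a higher number. Going by the values given here, no measured compound has an aromatic ring on this carbon, so the size of the step is poorly constrained and the range is wide. The expected step is a 4.3-fold higher number from compound 2 to compound 3 (0.63 log units; beyond the scatter). Compound 3 is estimated at 3 mg/kg, with an expected range from 0.5 mg/kg to 18 mg/kg.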

Compound 3, dose for half-maximal effect: > 30 mg/kg
Compound 3 was reported as a limit (the forecaster's own chance of this, stated with the estimate: 10%); middle value at least 10-fold (1.00 log units) away from the limit.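

Compound 3 is a limit and not a number in this assay: the limit of > 30 mg/kg in this assay, at which 1 of the 3 values shown sits. Moving to 2-chloro-6-fluorophenyl on this aromatic carbon raises the number from either smaller group: replacing hydroxymethyl gives an at least 42-fold higher number from compound 2 to compound 3 (1.63 log units; beyond the scatter), and replacing methyl gives an at least 5.0-fold higher number from compound 1 to compound 3 (0.69 log units; beyond the scatter). The earlier step showed only that adding a hydroxy to the small chain lowers the number, whereas this result shows that the loss of that hydroxy does not cover the whole change, since compound 1 also has no hydroxy and still lies on the lower side of compound 3.

The compounds shown leave open whether the rise belongs to any aromatic ring on this carbon or to the 2-chloro-6-fluorophenyl group in particular, a distinction that plain phenyl would help to draw. Also open, as far as these compounds go, is whether the benefit seen with hydroxymethyl extends to other small groups here, such as aminomethyl or a carboxylic acid.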